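From 2-fluorophenyl to 4-chlorophenyl on the saturated ring carbon

The source may hold more compounds than are shown below. What is called first, only, known or untested is meant among the compounds shown, and "the series" means these compounds.

For the measured compounds named here, in an ADME assay on BHK-21 cells (Mesocricetus auratus) for cytotoxicity, read by MTT assay, with a stated time of 72 h (a lower number here means that less compound is tolerated, a higher number that more compound is tolerated), compound 1 `NS(=O)(=O)c1ccc(N2N=C(c3ccc(Oc4ccccc4)cc3)CC2c2ccc(F)cc2)cc1` gives 8000 nM and compound 2 `NS(=O)(=O)c1ccc(N2N=C(c3ccc(Oc4ccccc4)cc3)CC2c2ccccc2F)cc1` gives 32000 nM, the higher of the two numbers so far. Compound 3 `NS(=O)(=O)c1ccc(N2N=C(c3ccc(Oc4ccccc4)cc3)CC2c2ccc(Cl)cc2)cc1` keeps the shared core and carries 4-chlorophenyl in place of 2-fluorophenyl on a saturated ring carbon, next to the ring nitrogen: 4-chlorophenyl in place of 2-fluorophenyl on a saturated ring carbon.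

Going by the values given here, only one measured step bears on this change: a 4.0-fold higher number from compound 1 to compound 2 (0.60 log units; beyond the scatter). It is modest but beyond the scatter, and it comes from replacing 4-fluorophenyl with 2-fluorophenyl at the same place. Compound 3 again has its aryl group substituted at the 4 position, so compound 1 at 8000 nM is the nearer reference. Among the compounds with values here, no measured pair shows chlorine replacing fluorine, which leaves the effect of that exchange open and the range wide. A step of similar size in the opposite direction is therefore expected in this assay, toward a lower number. The expected step is a 4.0-fold lower number from compound 2 to compound 3 (0.60 log units; beyond the scatter). Compound 3 is estimated at 8000 nM, with an expected range of 3000 nM to 22000 nM.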

Compound 3, half-maximal cytotoxic concentration: 7000 nM
The estimate for compound 3 lay 1.1-fold (0.06 log units) above the measured number; low and high end bracket the measured number.
By their numbers in this assay, from the lowest: compounds 3 and 1 (each within the scatter of the next); then compound 2.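

In this assay, the step of a 1.1-fold lower number from compound 1 to compound 3 (0.06 log units; within the scatter) shows that chloro and fluoro on this aromatic carbon cannot be told apart, so 4-chlorophenyl and 4-fluorophenyl stand level on the saturated ring carbon. The step of a 4.6-fold lower number from compound 2 to compound 3 (0.66 log units; beyond the scatter) stands beside the earlier step of a 4.0-fold higher number from compound 1 to compound 2 (0.60 log units; beyond the scatter), and both are beyond the scatter, so among these three compounds only compound 2, with its 2-fluorophenyl group, stands apart, at the high end of the series. No measurement shown here gives a reason for this separation.

Open, from the compounds shown here alone, is whether 2-chlorophenyl would stay with 2-fluorophenyl at the high end, which would tie the higher number to the substitution place on the aryl ring rather than to fluorine, and where plain phenyl would fall relative to the halogen-bearing groups. Also open, going by these compounds, is whether a non-halogen group on the aryl ring, such as methoxy or an amine, would stay level with 4-chlorophenyl and 4-fluorophenyl, and whether the same separation would hold with changes elsewhere on the shared core.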